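One More 2-Hydroxyphenyl on the Shared Core

The source may hold more compounds than are shown below. What is called first, only, known or untested is meant among the compounds shown, and "the series" means these compounds.

Compound 1 `Oc1cccc(-c2cc(-c3cccc(O)c3)nc(-c3ccccc3O)c2)c1` — a functional assay on DU-145 cells (Homo sapiens) for cytotoxicity, read by CCK-8 assay, with a stated time of 4 days; on this read-out lower numbers stand for stronger inhibition and higher numbers for weaker inhibition: > 50000 nM, a limit of the assay.
Compound 2 `Oc1cccc(-c2cc(-c3cccc(O)c3)nc(-c3cccc(O)c3)c2)c1` — this assay: 4040 nM.
Compound 3 `Oc1ccc(-c2cc(-c3cccc(O)c3)cc(-c3ccccc3O)n2)cc1` — this assay: > 50000 nM, a limit of the assay.

Compound 1 stands at the limit of this assay and gives no number; it shares that limit with compound 3, as the limit of > 50000 nM in this assay, at which 2 of the 3 values shown sit, shows. For the measured compounds named here, the only compound with a number is compound 2, and the step of an at least 12-fold lower number from compound 1 to compound 2 (1.09 log units; beyond the scatter) shows that exchanging the 2-hydroxyphenyl for a third 3-hydroxyphenyl brings the number down sharply. The step that the two limits leave unreadable from compound 1 to compound 3 cannot be read from the two limits.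

Compound 4 `Oc1cccc(-c2cc(-c3ccccc3O)cc(-c3ccccc3O)n2)c1` reverses that direction: 2-hydroxyphenyl in place of 3-hydroxyphenyl on an aromatic carbon. Compound 4 therefore carries two 2-hydroxyphenyl groups where compound 1 carries one. Going by the values given here, the one readable step, from compound 1 to compound 2, ran the other way and was large, so nothing points toward a lower number for compound 4. The expected outcome for compound 4 is that this assay again reports only its limit, with an estimated step that the limit leaves unreadable from compound 1 to compound 4. Compound 4 is estimated at 90000 nM, within 30000 nM to 300000 nM.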

Compound 4, half-maximal inhibitory concentration: 3980 nM
For compound 4 the middle estimate is 23-fold (1.35 log units) above the measured one; measured number below the stated range.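

Opposite the ring nitrogen, 2-hydroxyphenyl in place of 3-hydroxyphenyl gives an at least 12-fold lower number from compound 1 to compound 4 (1.09 log units; beyond the scatter) in this assay. The earlier readable step had lowered the number by exchanging a 2-hydroxyphenyl elsewhere on the shared core, whereas here a 2-hydroxyphenyl entering at this position lowers it too, so the effect of this group depends on where it stands. The step has no upper bound, since compound 1 gives only a limit, a limit also seen elsewhere in this set: the limit of > 50000 nM in this assay, at which 2 of the 4 values shown sit.

On these data alone, what stays open is whether the hydroxyl matters at this position at all, as an unsubstituted phenyl there would show. As far as these compounds go, how a methoxyphenyl or an aminophenyl opposite the ring nitrogen would read in this assay also remains open.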